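The source may hold more compounds than are shown below. What is called first, only, known or untested is meant among the compounds shown, and "the series" means these compounds.

Measured compounds:
Compound 1 `Cc1cc(C(=O)O)nn1Cc1cc(Br)ccc1OCc1ccccc1` gives 6.46 nM
Compound 2 `Cc1cc(C(=O)O)nn1Cc1cc(Br)ccc1OCc1ccc(Cl)cc1` gives 8.71 nM
Compound 3 `Cc1cc(C(=O)O)nn1Cc1cc(Br)ccc1OCc1ccc(F)cc1` gives 7.41 nM

Among these three, in an assay on CHO-K1 cells for displacement of a labelled ligand from prostaglandin E2 receptor EP1 subtype (Homo sapiens) (on this read-out higher numbers stand for weaker inhibition and lower numbers for stronger inhibition), compound 3 holds the second highest number. Its nearest neighbour is compound 1, with a 1.1-fold higher number from compound 1 to compound 3 (0.06 log units; within the scatter), and its furthest is compound 2, with a 1.2-fold lower number from compound 2 to compound 3 (0.07 log units; within the scatter). All three compounds share the same core and differ only in the substituent on the outer benzene ring of the benzyloxy group.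

The next compound, compound 4 `Cc1cc(C(=O)O)nn1Cc1cc(Br)ccc1OCc1ccc(C(F)(F)F)cc1`, carries the change (trifluoromethyl in place of fluoro on an aromatic carbon). Among the measured compounds shown here, three measured steps bear on this change, since each of them alters only the same ring position: a 1.3-fold higher number from compound 1 to compound 2 (0.13 log units; within the scatter), a 1.1-fold higher number from compound 1 to compound 3 (0.06 log units; within the scatter) and a 1.2-fold lower number from compound 2 to compound 3 (0.07 log units; within the scatter). Hydrogen, fluoro and chloro at this position all gave numbers that could not be told apart from one another. Trifluoromethyl is a larger group than any of the three already seen, so the comparison reaches somewhat beyond the measured range, but nothing in the data points to a shift in either direction.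

Compound 4 is therefore expected to give a number close to that of compound 3, with a 1.2-fold higher number from compound 3 to compound 4 (0.08 log units; within the scatter). The estimate for compound 4 in this assay is 9 nM, within a range from 4 nM to 22 nM.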

Compound 4, half-maximal inhibitory concentration: 35.5 nM
The estimate for compound 4 lay 3.9-fold (0.60 log units) below the measured number, and the stated range ends below it.
By their numbers in this assay, from the lowest: compounds 1, 3 and 2 (each within the scatter of the next); then compound 4.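

In this assay this position does not accept every group equally: hydrogen, fluoro and chloro could not be told apart here, but trifluoromethyl separates from all three, with a 4.8-fold higher number from compound 3 to compound 4 (0.68 log units; beyond the scatter) and a 4.1-fold higher number from compound 2 to compound 4 (0.61 log units; beyond the scatter) and also a 5.5-fold higher number from compound 1 to compound 4 (0.74 log units; beyond the scatter) as its steps. Each of these steps lies beyond the scatter, so the flat picture given by the first three compounds holds only for those small substituents, and the first real weakening of inhibition at this position appears with a group of 4 heavy atoms in place of 1. No measurement at hand explains why trifluoromethyl behaves differently from fluoro and chloro, so the result records the drop without giving a reason for it.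

The compounds shown leave open whether the weakening belongs to trifluoromethyl alone or would also appear with other groups at this position, such as methyl, methoxy, a nitrile or a tert-butyl group. They also leave open whether an amine or a hydroxyl group here would keep the numbers of compounds with hydrogen, fluoro and chloro or move them further.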